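The source may report more compounds than this note shows. Statements on the series, on what has been measured and on what is new or still open speak of the compounds shown alone.

Measured compounds:
Compound 1 `C#CCn1nnc2c(C(N)=O)ncn2c1=O`: 35600 nM
Compound 2 `Cc1cc(Cn2nnc3c(C(N)=O)ncn3c2=O)on1`: > 50000 nM
Compound 3 `Cc1noc(Cn2nnc3c(C(N)=O)ncn3c2=O)n1`: > 50000 nM

Among the compounds with values here, in a functional assay on SNB-19 cells (Homo sapiens) for inhibition, read by MTT assay, with a stated time of 7 days (on this read-out higher numbers stand for weaker inhibition of growth and lower numbers for stronger inhibition of growth), compound 1 gives 35600 nM, the only outright number among the three. Compound 2 reaches only > 50000 nM, which is a limit of the assay and not a number. Compound 3 likewise stops at > 50000 nM, also a limit. The two steps away from compound 1 are therefore both floors: an at least 1.4-fold higher number from compound 1 to compound 2 (0.14 log units; that floor lies within the scatter) and an at least 1.4-fold higher number from compound 1 to compound 3 (0.14 log units; that floor lies within the scatter). Between the two ring compounds nothing can be read, a step that the two limits leave unreadable from compound 2 to compound 3, since both sit at the limit of > 50000 nM in this assay, at which 2 of the 3 values shown sit.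

Compound 4 `NC(=O)c1ncn2c(=O)n(Cc3c[nH]nn3)nnc12` has not yet been measured in this assay. It differs from compound 1 thus: 1H-1,2,3-triazol-4-yl in place of ethynyl on a saturated chain carbon bound to an aromatic nitrogen. The two measured steps that bear on it, exchange of ethynyl for a small five-membered aromatic ring, both moved the number to the limit. A step of similar direction is expected, a 1.7-fold higher number from compound 1 to compound 4 (0.23 log units; within the scatter), with a fair chance that only a limit is reported. Compound 4 is estimated at 60000 nM, between 25000 nM and 150000 nM.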

Compound 4, concentration for 50% growth inhibition: > 50000 nM
Compound 4: only a limit was reported; the forecaster's own chance of this, stated with the estimate: 60%; the middle value lies beyond the limit too.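

In this assay compound 4 also stops at > 50000 nM and that value is a limit of the assay, not a number. Within the data shown here, the only readable step is an at least 1.4-fold higher number from compound 1 to compound 4 (0.14 log units; that floor lies within the scatter) and it is merely a floor, while the steps from compound 2 and compound 3 to compound 4 cannot be read. What is new is that 1H-1,2,3-triazol-4-yl, a ring with a hydrogen-bond donor where ethynyl has none, also gives no number on this saturated chain carbon bound to an aromatic nitrogen, and the compounds now gather at one value: the limit of > 50000 nM in this assay, at which 3 of the 4 values shown sit.

From the compounds shown here alone, whether any ring compound truly lies apart from compound 1 stays open, since each floor remains within the scatter. Also open, going by these compounds, is how an amine, a carboxylic acid or a longer chain such as but-3-ynyl would read in place of propargyl.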